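A few compounds are considered here, and "the series" means these few. Any claim that something is new, unique, unknown or untested is made for them only; others in the source may bear on it.

Measured in a functional assay on MCF7 cells (Homo sapiens) for inhibition, with a stated time of 72 h; a lower number here means a stronger inhibitor, a higher number a weaker inhibitor:
Compound 1 `NC1CCC(Nc2nc(NCc3ccc(-c4ccccc4)cc3)c3ncn(C4CCCC4)c3n2)CC1`: 583 nM
Compound 2 `NC1CCC(Nc2nc(NCc3ccc(-n4cccn4)cc3)c3ncn(C4CCCC4)c3n2)CC1`: 139 nM
Compound 3 `NC1CCC(Nc2nc(NCc3ccc(-c4ccccc4O)cc3)c3ncn(C4CCCC4)c3n2)CC1`: 2910 nM

Of these three, compound 2 has the lowest number and is the strongest inhibitor, with both other compounds standing higher by more than the scatter. Compound 4 `Nc1ccccc1CNc1nc(NC2CCC(N)CC2)nc2c1ncn2C1CCCC1` has not yet been measured. Its difference from compound 2 is 2-aminophenyl in place of 4-(1H-pyrazol-1-yl)phenyl on a saturated chain carbon bound to a nitrogen on an aromatic ring.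

For the measured compounds named here, no measured step makes this exact exchange, and no measured compound carries a single ring in this group. Going by the values given here, three steps bear on it indirectly. The modest 4.2-fold lower number from compound 1 to compound 2 (0.62 log units; beyond the scatter) came with 1H-pyrazol-1-yl in place of phenyl on an aromatic carbon. The modest 5.0-fold higher number from compound 1 to compound 3 (0.70 log units; beyond the scatter) came with hydroxy in place of hydrogen on an aromatic carbon. The closest comparison is the large 21-fold higher number from compound 2 to compound 3 (1.32 log units; beyond the scatter), where 2-hydroxyphenyl replaced 1H-pyrazol-1-yl. Since both measured departures from compound 2 gave higher numbers, a modest to large rise is expected in this assay, though with wide uncertainty. The expected change is an 11-fold higher number from compound 2 to compound 4 (1.03 log units; beyond the scatter). For compound 4 the estimated value is 1500 nM, with an expected range of 350 nM to 6000 nM.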

Compound 4, half-maximal inhibitory concentration: 2330 nM
Compound 4: the middle estimate sits 1.6-fold (0.19 log units) below what was measured; measured number inside the range.
By their numbers in this assay, from the lowest: compound 2; then compound 1; then compounds 4 and 3 (each within the scatter of the next).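

Until compound 4, the group on a saturated chain carbon bound to a nitrogen on an aromatic ring had always held two aromatic rings, and the 2-aminophenyl group brings the first single ring to this place. In this assay it gives a 17-fold higher number from compound 2 to compound 4 (1.22 log units; beyond the scatter) and a 4.0-fold higher number from compound 1 to compound 4 (0.60 log units; beyond the scatter), so this single ring with its amine stands clearly above both compounds with the unsubstituted second ring, while its number lies within the scatter of the number for compound 3, which keeps two rings and carries a hydroxy group. A two-ring group is therefore not the only kind that reaches this level in this assay, and nothing in the available data accounts for these shifts.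

The compounds shown leave open how much of the rise from compound 2 belongs to the loss of the 1H-pyrazol-1-yl ring and how much to the amine, since the two changes arrive together in compound 4. A plain phenyl at this place, or a phenyl carrying a hydroxy group or a carboxylic acid in place of the amine, would pull these two changes apart.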